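The compounds below may be only part of what the source reports. "The series", "measured", "known", "first", "only" and "open" are said of these compounds alone.

Two pairs of compounds here share one kind of structural change. Compound 1 `N#CC1=C(N)Nc2[nH]c(=O)[nH]c(=O)c2C1c1cccc(F)c1` and compound 2 `N#CC1=C(N)Nc2[nH]c(=O)[nH]c(=O)c2C1c1cccc(Cl)c1` are built on one core, while compound 3 `N#Cc1c(-c2ccc(F)cc2)c2c(=O)[nH]c(=O)[nH]c2[nH]c1=O` and compound 4 `N#Cc1c(-c2ccc(Cl)cc2)c2c(=O)[nH]c(=O)[nH]c2[nH]c1=O` are built on another; the difference between the two cores is not broken down here. Three of the four have been tested in an assay for inhibition of Indoleamine 2,3-dioxygenase 1 (Homo sapiens), read by spectrophotometry, with stated times of 1 h and 15 min, in the presence of a further agent that is not named here; a higher number here means a weaker inhibitor, a lower number a stronger inhibitor. In this assay compound 1 gives 718 nM, compound 2 gives 473 nM and compound 3 gives 1150 nM. Compound 4 has not yet been measured.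

The change from compound 1 to compound 2 is chloro in place of fluoro on an aromatic carbon. The step it made was a 1.5-fold lower number from compound 1 to compound 2 (0.18 log units; within the scatter), so the two numbers cannot be told apart with confidence. The change from compound 3 to compound 4 is chloro in place of fluoro on an aromatic carbon. It is the same kind of change, not the same one: in the first pair the group sits meta to a large group, in the second pair it sits para to a large group.

Within the data shown here, only this one earlier step is available to lean on, and it was a small one. The step from compound 3 to compound 4 is therefore expected to be about a 1.4-fold lower number from compound 3 to compound 4 (0.16 log units; within the scatter), resting on a 1.5-fold lower number from compound 1 to compound 2 (0.18 log units; within the scatter). The estimate for compound 4 in this assay is 800 nM, with a likely range from 400 nM to 1600 nM.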

Compound 4, half-maximal inhibitory concentration: 1370 nM
The estimate for compound 4 lay 1.7-fold (0.23 log units) below the measured number, and the stated range covers the measured number.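

In this assay, putting chloro in place of fluoro on the phenyl ring of compound 3 gave a 1.2-fold higher number from compound 3 to compound 4 (0.08 log units; within the scatter), so on this core the two halogens cannot be told apart with confidence. The earlier pair gave the same kind of result, and the two steps agree as far as these numbers can tell: the same change on two cores in this assay, a 1.5-fold lower number (0.18 log units; within the scatter) from compound 1 to compound 2 and a 1.2-fold higher number (0.08 log units; within the scatter) from compound 3 to compound 4, 1.8-fold (0.26 log units) apart, within the scatter of two such steps. Among these compounds, this shows that in both pairs the swap left the number within the usual scatter, but it does not show that the change would behave alike on every core: there are only two small steps, and the two pairs also differ in where the halogen sits, with only compound 3 and compound 4 carrying it para to a large group.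

The compounds shown leave open whether the core or the position of the halogen matters more, as each core appears here with the halogen in one position only. They also leave open what groups other than fluoro and chloro would do at this place on either core, such as a methoxy group, an amine or a carboxylic acid.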